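Trimethoxyphenyl ketones on a thiazole core: the para substituent

The source may hold more compounds than are shown below. What is called first, only, known or untested is meant among the compounds shown, and "the series" means these compounds.

Measured so far in a functional assay on LNCaP cells (Homo sapiens) for cytotoxicity, read by sulforhodamine B assay, with a stated time of 48 h; a higher number here means a weaker inhibitor, a lower number a stronger inhibitor:
- compound 1 `CCc1ccc(-c2nc(C(=O)c3cc(OC)c(OC)c(OC)c3)cs2)cc1`: 60 nM
- compound 2 `COc1cc(NC(=O)[C@@H]2CSC(c3ccccc3)=N2)cc(OC)c1OC`: > 20000 nM, a limit of the assay, not a number
- compound 3 `COc1cc(NC(=O)[C@@H]2CSC(c3ccccc3)N2)cc(OC)c1OC`: > 20000 nM, also a limit, not a number

Among the compounds with values here, compound 1 is the only compound of the three with a measured number in this assay. For compound 2 the result is a limit. For compound 3 the result is likewise a limit; see (the limit of > 20000 nM in this assay, at which 2 of the 3 values shown sit). Within the data shown here, no pair of measured compounds differs in one place, so no measured step is available.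

Compound 4 `COC(=O)c1ccc(-c2nc(C(=O)c3cc(OC)c(OC)c(OC)c3)cs2)cc1` follows from compound 1 by one change: methoxycarbonyl in place of ethyl on an aromatic carbon. The trimethoxybenzoyl ketone and the core of compound 1 are kept; only the group on the six-membered aromatic ring of carbon only, para to a large group, changes. Among the measured compounds shown here, since the only measured number stands for compound 1 at 60 nM, the expectation rests on that alone. For the measured compounds named here, a moderate loss in this assay is expected, a 5.0-fold higher number from compound 1 to compound 4 (0.70 log units; beyond the scatter), rather than a gain, although the data give no measured step to support this. Compound 4 is therefore estimated at 300 nM, within 80 nM to 2000 nM.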

Compound 4, half-maximal inhibitory concentration: > 20000 nM
Compound 4: a limit, no number (the forecaster's own chance of this, stated with the estimate: 5%); at least 66-fold (1.82 log units) between middle value and limit.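

Within the data shown here, this is the first measured step: in this assay, methoxycarbonyl in place of ethyl on the aromatic carbon, para to a large group, gives an at least 330-fold higher number from compound 1 to compound 4 (2.52 log units; beyond the scatter). With the trimethoxybenzoyl ketone and the core of compound 1 kept, this single substituent alone separates a measured value from no measured value, so activity in this series depends strongly on the group at this place. As far as these compounds go, the result for compound 4 is a limit, not a number, so the full size of the loss stays unknown: the limit of > 20000 nM in this assay, at which 3 of the 4 values shown sit.

A single replacement cannot tell whether the loss follows from the carbonyl, the added oxygen atoms or the larger group. From the compounds shown here alone, how a propyl chain, a methoxy group, an amine or a carboxylic acid would fare at this place remains open.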